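The compounds below may be only part of what the source reports. "The series", "measured", "known", "first", "only" and "open" are said of these compounds alone.

For the measured compounds named here, compound 3, `CCCCCCCCCCCCCCCCCCNC(=O)[C@@H](NC(=O)c1cc2ccccc2[nH]1)[C@@H](C)O`, gives 29600 nM in a functional assay on SiHa cells (Homo sapiens) for cytotoxicity, read by MTT assay, with a stated time of 48 h (a higher number here means a weaker inhibitor, a lower number a stronger inhibitor), the lowest of the three numbers measured so far, although its gaps to the other two both sit within the scatter: compound 1, `CCCCCCCCCCCCCCCCCCNC(=O)[C@@H](NC(=O)c1ccccc1)[C@@H](C)O`, gives 38200 nM, and compound 2, `CCCCCCCCCCCCCCCCCCNC(=O)[C@@H](NC(=O)c1nccc2ccccc12)[C@@H](C)O`, gives 51200 nM. The steps are a 1.3-fold lower number from compound 1 to compound 3 (0.11 log units; within the scatter) and a 1.7-fold lower number from compound 2 to compound 3 (0.24 log units; within the scatter). Compound 4, `CCCCCCCCCCCCCCCCCCNC(=O)[C@@H](NC(=O)/C=C/c1ccccc1)[C@@H](C)O`, carries a further swap at the same spot: 2-phenylethenyl in place of 1H-indol-2-yl on a carbonyl carbon. Every change of the group on that carbonyl carbon seen so far, including a 1.3-fold higher number from compound 1 to compound 2 (0.13 log units; within the scatter), stayed within the scatter, so no movement beyond it is expected here either. Compound 4 is therefore expected to give about 35000 nM in this assay, somewhere between 15000 nM and 80000 nM. The expected step is a 1.2-fold higher number from compound 3 to compound 4 (0.07 log units; within the scatter).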

Compound 4, half-maximal inhibitory concentration: 35900 nM
The estimate for compound 4 lay 1.0-fold (0.01 log units) below the measured number; the measured number falls inside the stated range.
By their numbers in this assay, from the lowest: compounds 3, 4, 1 and 2 (each within the scatter of the next).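

Swapping in 2-phenylethenyl, which brings a double bond outside the aromatic rings and lacks the hydrogen-bond donor of 1H-indol-2-yl, still leaves the number in this assay within the scatter of all three earlier compounds (a 1.2-fold higher number from compound 3 to compound 4 (0.08 log units; within the scatter); a 1.4-fold lower number from compound 2 to compound 4 (0.15 log units; within the scatter); a 1.1-fold lower number from compound 1 to compound 4 (0.03 log units; within the scatter)). So a group on this carbonyl carbon need not be joined directly to an aromatic ring for the number to stay in this range. No supporting measurement explains this.

On these data alone, whether an amine or a carboxylic acid in this place would move the number beyond the scatter remains open, as does the effect of a shorter chain.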